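Swapping the sulfur substituent of compound 3 for a hydroxyalkyl chain

The source may report more compounds than this note shows. Statements on the series, on what has been measured and on what is new or still open speak of the compounds shown alone.

Measured compounds:
- compound 1, `CC(C)c1n[nH]c2c(NCc3ccc(-c4ccccn4)cc3)nc(SCC(O)CN)nc12`: 55 nM
- compound 2, `CC(C)c1n[nH]c2c(NCc3ccc(-c4ccccn4)cc3)nc(SCCCN(C)C)nc12`: 105 nM
- compound 3, `CC(C)c1n[nH]c2c(NCc3ccc(-c4ccccn4)cc3)nc(SCC(N)=O)nc12`: 192 nM

All three share one core and differ only in the group carried on the sulfur. In a functional assay on HT cells (Homo sapiens) for antiproliferative activity, read by fluorescence, with a stated time of 72 h (a lower number here means a stronger inhibitor of growth, a higher number a weaker inhibitor of growth), compound 3 gives the highest of the three numbers; its nearest neighbour is compound 2, a 1.8-fold higher number from compound 2 to compound 3 (0.26 log units; within the scatter), and its furthest is compound 1, a 3.5-fold higher number from compound 1 to compound 3 (0.54 log units; beyond the scatter).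

Compound 4, `CCC(CO)Sc1nc(NCc2ccc(-c3ccccn3)cc2)c2[nH]nc(C(C)C)c2n1`, has not yet been measured. It differs from compound 3 in one place: 1-(hydroxymethyl)propyl in place of carbamoylmethyl on a sulfur. The carbamoylmethyl group leaves the sulfur and 1-(hydroxymethyl)propyl enters, on the sulfur whose other neighbour is an aromatic carbon.

Within the data shown here, the steps that bear on this are the two changes at the same sulfur: a 3.5-fold higher number from compound 1 to compound 3 (0.54 log units; beyond the scatter) and a 1.8-fold higher number from compound 2 to compound 3 (0.26 log units; within the scatter). Both run from chains carrying a hydroxy or an amine toward the carbamoyl, and both give higher numbers, one modest, one within the scatter. Reversing direction toward a hydroxy-bearing chain, compound 4 is expected to give a somewhat lower number than compound 3, a 1.5-fold lower number from compound 3 to compound 4 (0.17 log units; within the scatter), though the step may stay within the scatter. The estimate for compound 4 is 130 nM, with a range from 55 nM to 350 nM.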

Compound 4, concentration for 50% growth inhibition: 255 nM
Beside the measured number, compound 4's estimate is 2.0-fold (0.29 log units) below it; low and high end bracket the measured number.
By their numbers in this assay, from the lowest: compounds 1, 2, 3 and 4 (each within the scatter of the next, the first and the last beyond it).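

In this assay, a hydroxy group on the sulfur substituent does not by itself bring the number down: 1-(hydroxymethyl)propyl and carbamoylmethyl cannot be told apart (a 1.3-fold higher number from compound 3 to compound 4 (0.12 log units; within the scatter)). The steps from the two amine-bearing chains are larger and beyond the scatter (a 2.4-fold higher number from compound 2 to compound 4 (0.39 log units; beyond the scatter); a 4.6-fold higher number from compound 1 to compound 4 (0.67 log units; beyond the scatter)), so both 3-(dimethylamino)propyl and 3-amino-2-hydroxypropyl give lower numbers than this hydroxy chain without an amine, although compound 3, which has no amine either, stays within the scatter of compound 2. No measurement shown explains why these chains differ.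

From the compounds shown here alone, it remains open whether a 3-hydroxypropyl chain, with a hydroxy group but no amine, would come close to compound 1. Going by these compounds, what a carboxylic acid at the end of the chain would give also remains unknown.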